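Chain extension in a thioether aminoquinazoline pair

The source may report more compounds than this note shows. Statements on the series, on what has been measured and on what is new or still open speak of the compounds shown alone.

Measured so far:
compound 1 `CSc1nc(NCCCc2ccccc2)c2ccccc2n1` — > 100000 nM
compound 2 `COc1ccc(CNc2nc(SC)nc3ncccc23)cc1` — > 100000 nM

In a functional assay on MCF7 cells (Homo sapiens) for cytotoxicity, read by MTT assay, with a stated time of 72 h (on this read-out higher numbers stand for weaker inhibition of growth and lower numbers for stronger inhibition of growth), compound 1 gives only a limit, > 100000 nM. Compound 2, a different core, also gives only a limit, > 100000 nM. Both values sit at the limit of > 100000 nM in this assay, at which 2 of the 2 values shown sit. Compound 3 `CSc1nc(NCCCCc2ccccc2)c2ccccc2n1` carries benzyl in place of phenyl on a saturated chain carbon, three bonds along the chain from a nitrogen on an aromatic ring. Going by the values given here, with compound 1 at the limit, no step between measured compounds exists to anchor the change; a shift beyond the scatter is not expected, and the likeliest outcome is another limit. The estimate for compound 3 is 120000 nM (range 40000 nM to 400000 nM), an expected step that the limit leaves unreadable from compound 1 to compound 3.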

Compound 3, concentration for total growth inhibition: 64000 nM
For compound 3 the middle estimate is 1.9-fold (0.27 log units) above the measured one; the range from low to high includes it.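

Going by these compounds alone, compound 3 gives the first number in this set rather than a limit: the change to benzyl on the saturated chain brings the read-out in this assay within the measurable range. The change amounts to an at least 1.5-fold lower number from compound 1 to compound 3 (0.19 log units; that floor lies within the scatter). Its true size remains unread, and the limit still dominates the set: the limit of > 100000 nM in this assay, at which 2 of the 3 values shown sit.

Open, going by these compounds, is whether a longer chain at this place would lower the number further, or whether an amine on the terminal ring would shift it. Also open, on these data alone, is whether benzyl in place of phenyl behaves alike on other cores.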